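The source may report more compounds than this note shows. Statements on the series, on what has been measured and on what is new or still open speak of the compounds shown alone.

Measured in an assay on brain for displacement of a labelled ligand from Adrenergic receptor alpha-1 (Rattus norvegicus); a lower number here means a stronger inhibitor, a higher number a weaker inhibitor:
compound 1, `CCOCCOC1CCN(c2nc(N)c3cc(OC)c(OC)cc3n2)CC1`: 1.81 nM
compound 2, `COc1cc2nc(N3CCC(OCCO)CC3)nc(N)c2cc1OC`: 2.2 nM
compound 3, `CCOC(C)COC1CCN(c2nc(N)c3cc(OC)c(OC)cc3n2)CC1`: 0.99 nM

Compound 3 has the lowest of the three numbers; the step of a 1.8-fold lower number from compound 1 to compound 3 (0.26 log units; within the scatter) lies within the scatter, while the step of a 2.2-fold lower number from compound 2 to compound 3 (0.35 log units; beyond the scatter) is modest and beyond it. Compound 4, `COc1cc2nc(N3CCC(OCC(C)O)CC3)nc(N)c2cc1OC`, is not yet measured. It differs from compound 3 by hydrogen in place of ethyl on an oxygen on a saturated carbon. The same change occurs once already among the measured compounds, as hydrogen in place of ethyl on an oxygen on a saturated carbon, with the step of a 1.2-fold higher number from compound 1 to compound 2 (0.08 log units; within the scatter). The two cores differ by methyl in place of hydrogen on a saturated chain carbon bound to an oxygen on a saturated carbon and a saturated chain carbon. The place is the same word for word in both pairs, so this is the same change. Since that earlier step was within the scatter, a step of about a 1.2-fold higher number from compound 3 to compound 4 (0.08 log units; within the scatter) is expected in this assay. Compound 4 is therefore estimated at 1.2 nM, most likely between 0.6 nM and 2.5 nM.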

Compound 4, inhibition constant: 3.52 nM
For compound 4 the middle estimate is 2.9-fold (0.47 log units) below the measured one, and the stated range ends below it.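

In this assay, the step for hydrogen in place of ethyl does not carry over in size from one core to the other, with a 3.6-fold higher number from compound 3 to compound 4 (0.55 log units; beyond the scatter): the same change on two cores in this assay, a 1.2-fold higher number (0.08 log units; within the scatter) from compound 1 to compound 2 and a 3.6-fold higher number (0.55 log units; beyond the scatter) from compound 3 to compound 4, 2.9-fold (0.47 log units) apart, beyond the scatter of two such steps. Methyl in place of hydrogen likewise depends on the core, with a 1.6-fold higher number from compound 2 to compound 4 (0.20 log units; within the scatter) set against the step on the ethoxy pair: the same change on two cores in this assay, a 1.8-fold lower number (0.26 log units; within the scatter) from compound 1 to compound 3 and a 1.6-fold higher number (0.20 log units; within the scatter) from compound 2 to compound 4, 2.9-fold (0.47 log units) apart, beyond the scatter of two such steps. The remaining step, a 1.9-fold higher number from compound 1 to compound 4 (0.29 log units; within the scatter), is also within the scatter, and these four compounds show that the two changes do not combine independently, but not why, nor whether this extends beyond these compounds.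

From the compounds shown here alone, whether the same dependence on the core holds for a methoxy or propoxy ether, or for an amine in place of the hydroxy, stays open.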